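Pyrazole Substitution Pattern at the Amide Nitrogen

This account rests on a few compounds, and the source may have more. Where it says the series, first, only, none or still open, it means among the compounds named here.

Measured compounds:
Compound 1, `Cc1ccc(OCC(=O)N(Cc2cccs2)C2COC2)cc1`: 23000 nM
Compound 2, `Cc1ccc(OCC(=O)N(Cc2cccs2)c2ccn[nH]2)cc1`: 0.2 nM

Both compounds were tested in an assay on HEK293 cells for agonist activity at transient receptor potential cation channel subfamily M member 8 (Homo sapiens), read by fluorescence and calcium flux, with a stated time of 15 min; on this read-out lower numbers stand for an effect already at smaller amounts and higher numbers for an effect only at larger amounts of compound. Compound 2 stands at the low end of the two numbers; its nearest neighbour is compound 1, and the change a 120000-fold lower number from compound 1 to compound 2 (5.06 log units; beyond the scatter) is far beyond the scatter. Compound 3, `Cc1ccc(OCC(=O)N(Cc2cccs2)c2c(C)n[nH]c2C)cc1`, has not been measured. It differs from compound 2 by 3,5-dimethyl-1H-pyrazol-4-yl in place of 1H-pyrazol-5-yl on an amide-type nitrogen. For the measured compounds named here, no measured step touches this exact change; the only measured step concerns the same amide-type nitrogen and shows how sensitive this position is, so a shift beyond the scatter is plausible in either direction. A moderate loss is the expected outcome, estimated as a 15-fold higher number from compound 2 to compound 3 (1.18 log units; beyond the scatter). Compound 3 is therefore expected to give about 3 nM, with a range from 0.2 nM to 50 nM.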

Compound 3, half-maximal effective concentration: 0.3 nM
The estimate for compound 3 lay 10-fold (1.00 log units) above the measured number, and the stated range covers the measured number.
By their numbers in this assay, from the lowest: compounds 2 and 3 (each within the scatter of the next); then compound 1.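

In this assay, 3,5-dimethyl-1H-pyrazol-4-yl in place of 1H-pyrazol-5-yl on the amide-type nitrogen gives a 1.5-fold higher number from compound 2 to compound 3 (0.18 log units; within the scatter), so among these compounds the position accepts a second pyrazole with a different attachment and more heavy atoms without a change beyond the scatter. The large step seen earlier is also not tied to 1H-pyrazol-5-yl alone: replacing oxetan-3-yl with the dimethyl pyrazole gives a 77000-fold lower number from compound 1 to compound 3 (4.88 log units; beyond the scatter), a step of the same large kind. Nothing available here explains why the pyrazoles and oxetan-3-yl differ so widely.

The compounds shown leave open how a phenyl group or a primary amine on this nitrogen would compare with the two pyrazoles. They also leave open whether a single methyl on the pyrazole would read like 3,5-dimethyl-1H-pyrazol-4-yl in this assay.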